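Thiophene for Phenyl: Clearance Outlook for Compound 3

A few compounds are considered here, and "the series" means these few. Any claim that something is new, unique, unknown or untested is made for them only; others in the source may bear on it.

Compound 1 `CCc1cc(-c2noc(-c3cc(C)cc(CN(C)C)c3)n2)cc(C)c1OC[C@@H](O)CNC(=O)CO` is read in an ADME assay on liver (strain Wistar) for metabolic stability, with Liver microsome (Rattus norvegicus) as the target, read by LC-MS, using microsomes and NADPH, with a stated time of 15 min, tested at 1 uM (on this read-out lower numbers stand for slow clearance and higher numbers for fast clearance), only as a limit, > 4800 mL.min-1.g-1. Compound 2 `CCCCN(C)Cc1cc(C)cc(-c2nc(-c3cc(C)c(OC[C@@H](O)CNC(=O)CO)c(CC)c3)no2)c1` gives 7300 mL.min-1.g-1 in this assay, so the step that the limit leaves unreadable from compound 1 to compound 2 cannot be sized, as the limit of > 4800 mL.min-1.g-1 in this assay, at which 1 of the 2 values shown sits, shows. Compound 3 `CCc1cc(-c2noc(-c3cc(C)c(CN(C)C)s3)n2)cc(C)c1OC[C@@H](O)CNC(=O)CO` differs from compound 1 by 5-((dimethylamino)methyl)-4-methylthiophen-2-yl in place of 3-((dimethylamino)methyl)-5-methylphenyl on an aromatic carbon. For the measured compounds named here, no measured step bears on this change, and compound 1 itself stands only at a limit, so no direction beyond the scatter can be read from the measured pair. Compound 3 is expected to remain fast-clearing, with the step that the limit leaves unreadable from compound 1 to compound 3 estimated to give 5500 mL.min-1.g-1, between 2500 mL.min-1.g-1 and 9000 mL.min-1.g-1.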

Compound 3, intrinsic clearance in microsomes: 8100 mL.min-1.g-1
Estimate against measurement, compound 3: 1.5-fold (0.17 log units) below, within the range that was stated.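

No step from compound 1 to compound 3 can be read, because compound 1 stands only at a limit: the limit of > 4800 mL.min-1.g-1 in this assay, at which 1 of the 3 values shown sits.

The compounds shown leave open whether 5-((dimethylamino)methyl)-4-methylthiophen-2-yl in place of 3-((dimethylamino)methyl)-5-methylphenyl alters intrinsic clearance in microsomes at all.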